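Fluoro to methoxy on the aryl ring of compound 2

The compounds below may be only part of what the source reports. "The series", "measured", "known", "first", "only" and "open" are said of these compounds alone.

Compound 1 `Cc1nnc(SCC(=O)N/N=c2/scc(-c3ccc(F)cc3)n2-c2ccccc2)s1` gives 383 ug/mL in an ADME assay on NIH3T3 cells (Mus musculus) for cytotoxicity, read by MTT assay, with a stated time of 24 h; on this read-out higher numbers stand for weaker inhibition and lower numbers for stronger inhibition.
Compound 2 `Cn1nnnc1SCC(=O)N/N=c1/scc(-c2ccc(F)cc2)n1-c1ccccc1` gives 113 ug/mL in this assay.
Compound 3 `O=C(CSc1nnnn1-c1ccccc1)N/N=c1/scc(-c2ccc(F)cc2)n1-c1ccccc1` gives 207 ug/mL in this assay.

Compound 2 stands at the low end of these three numbers: a 1.8-fold higher number from compound 2 to compound 3 (0.26 log units; within the scatter) is within the scatter, while a 3.4-fold lower number from compound 1 to compound 2 (0.53 log units; beyond the scatter) is beyond it. Compound 4 `COc1ccc(-c2cs/c(=N/NC(=O)CSc3nnnn3C)n2-c2ccccc2)cc1` differs from compound 2 by methoxy in place of fluoro on an aromatic carbon. Within the data shown here, none of the measured steps touches this position; a 3.4-fold lower number from compound 1 to compound 2 (0.53 log units; beyond the scatter), a 1.9-fold lower number from compound 1 to compound 3 (0.27 log units; within the scatter) and a 1.8-fold higher number from compound 2 to compound 3 (0.26 log units; within the scatter) all concern the heteroaryl group on the sulfur, and the 4-fluorophenyl is kept throughout. The data therefore give no footing for a step in either direction in this assay. For compound 4 the expected value is 113 ug/mL, with a range of 45 ug/mL to 280 ug/mL. This estimate means no change at the digits printed from compound 2 to compound 4 (within the scatter), nothing beyond the scatter.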

Compound 4, half-maximal inhibitory concentration: 45 ug/mL
Beside the measured number, compound 4's estimate is 2.5-fold (0.40 log units) above it; the range from low to high includes it.
By their numbers in this assay, from the lowest: compound 4; then compounds 2, 3 and 1 (each within the scatter of the next, the first and the last beyond it).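

In this assay, among these compounds, the aryl position, which the earlier compounds left unchanged, proves able to move the number: 4-methoxyphenyl in place of 4-fluorophenyl gives a 2.5-fold lower number from compound 2 to compound 4 (0.40 log units; beyond the scatter) on the same 1-methyl-1H-tetrazol-5-yl background. So the heteroaryl group on the sulfur is not the only place where a single change shifts this read-out. Nothing measured here bears on why the number falls at this position.

From the compounds shown here alone, whether the step is particular to methoxy or would also appear with an amine, a hydroxyl or a longer alkoxy chain at this place remains open. So does whether it carries over to the 1-phenyl-1H-tetrazol-5-yl and 5-methyl-1,3,4-thiadiazol-2-yl series.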